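A few compounds are considered here, and "the series" means these few. Any claim that something is new, unique, unknown or untested is made for them only; others in the source may bear on it.

Three compounds share one core and differ only in the group sitting on an amine nitrogen in a ring. Compound 1 `COc1ccc(-c2cnc3nc(N)nc(N4CCN(C(=O)COc5ccccc5)CC4)c3n2)cc1OC` gives 4 nM in a functional assay on cells (T-cell, Homo sapiens) for inhibition; a lower number here means a stronger inhibitor, a higher number a weaker inhibitor. Compound 2 `COc1ccc(-c2cnc3nc(N)nc(N4CCN(c5ccc(F)cc5)CC4)c3n2)cc1OC` gives 100 nM. Compound 3 `COc1ccc(-c2cnc3nc(N)nc(N4CCN(Cc5ccccc5F)CC4)c3n2)cc1OC` gives 700 nM, the highest number of the three and so the weakest inhibitor here, as shown by a 180-fold higher number from compound 1 to compound 3 (2.24 log units; beyond the scatter) and a 7.0-fold higher number from compound 2 to compound 3 (0.85 log units; beyond the scatter). Compound 4 `COc1ccc(-c2cnc3nc(N)nc(N4CCN(c5ccc(C)cc5)CC4)c3n2)cc1OC` is not yet measured; (4-methylphenyl in place of 2-fluorobenzyl on an amine nitrogen in a ring). Of the measured steps, a 7.0-fold higher number from compound 2 to compound 3 (0.85 log units; beyond the scatter) bears on this most directly, as it exchanges the same kinds of group in the opposite direction. Reversing that change should lower the number by a modest step, expected as a 5.8-fold lower number from compound 3 to compound 4 (0.77 log units; beyond the scatter). Compound 4 is therefore estimated at 120 nM, with a likely range from 30 nM to 500 nM.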

Compound 4, half-maximal inhibitory concentration: 300 nM
Estimate against measurement, compound 4: 2.5-fold (0.40 log units) below; measured number inside the range.
By their numbers in this assay, from the lowest: compound 1; then compound 2; then compound 4; then compound 3.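

Swapping fluoro for methyl on the aromatic carbon of the phenyl group already makes inhibition weaker (a 3.0-fold higher number from compound 2 to compound 4 (0.48 log units; beyond the scatter)), so this small change at the end of the group matters. The 4-methylphenyl group still does better than 2-fluorobenzyl (a 2.3-fold lower number from compound 3 to compound 4 (0.37 log units; beyond the scatter)), but it falls far short of the (phenoxymethyl)carbonyl group (a 75-fold higher number from compound 1 to compound 4 (1.88 log units; beyond the scatter)), which remains the strongest of the four.

Nothing measured here explains these differences. Open questions are where a plain phenyl or a 4-methoxyphenyl would fall, and whether a simple benzoyl group would come close to compound 1.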